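Methoxy in Place of Bromo on the Urea Aryl Group

A few compounds are considered here, and "the series" means these few. Any claim that something is new, unique, unknown or untested is made for them only; others in the source may bear on it.

Compound 3 `O=C(NC[C@@H](O)C(=O)O)c1ccc(CN(C(=O)Nc2cc(Br)cc(C(F)(F)F)c2)c2ccc(C3=CCCCC3)cc2)cc1`, compound 1 `Cc1cc(C)cc(NC(=O)N(Cc2ccc(C(=O)NC[C@@H](O)C(=O)O)cc2)[C@H]2CC[C@H](C(C)(C)C)CC2)c1` and compound 2 `O=C(NC[C@@H](O)C(=O)O)c1ccc(CN(C(=O)Nc2cccc(Br)c2)c2ccc(C3CCCCC3)cc2)cc1` share one core and differ in the groups around the urea. In an in vitro assay on BHK cells for binding affinity to gastric inhibitory polypeptide receptor (Homo sapiens) (on this read-out higher numbers stand for weaker inhibition and lower numbers for stronger inhibition), compound 3 gives 380 nM, the highest of the three numbers; compound 1 gives 220 nM and compound 2 gives 216 nM, both within the scatter of compound 3. Compound 4 `COc1cc(NC(=O)N(Cc2ccc(C(=O)NC[C@@H](O)C(=O)O)cc2)c2ccc(C3=CCCCC3)cc2)cc(C(F)(F)F)c1` differs from compound 3 by methoxy in place of bromo on an aromatic carbon. Among the compounds with values here, no measured pair shows this change, so its effect is unknown from these data. The step from compound 3 to compound 4 is expected to be a 1.1-fold higher number from compound 3 to compound 4 (0.02 log units; within the scatter), nothing beyond the scatter. Compound 4 is estimated at 400 nM, with a range from 150 nM to 1100 nM.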

Compound 4, half-maximal inhibitory concentration: 279 nM
Compound 4: middle estimate off by 1.4-fold (0.16 log units), on the high side; low and high end bracket the measured number.
By their numbers in this assay, from the lowest: compounds 2, 1, 4 and 3 (each within the scatter of the next).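

In this assay, putting methoxy in place of bromo on this ring, meta to a trifluoromethyl group, gives a 1.4-fold lower number from compound 3 to compound 4 (0.13 log units; within the scatter). Within the data shown here, this is the first direct reading of the change, and it shows that this exchange, which brings in one hydrogen-bond acceptor, does not move the number beyond the usual scatter. Nothing available here speaks to the reason for this result. From the compounds shown here alone, it remains open whether an amine or a nitrile at this position would shift the number beyond the scatter, and whether methoxy would behave the same with a different group in place of the trifluoromethyl.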